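Bromophenyl Ester Expected to Share the Limit

A few compounds are considered here, and "the series" means these few. Any claim that something is new, unique, unknown or untested is made for them only; others in the source may bear on it.

Three esters of the shared core have been measured in a functional assay on DU-145 cells (Homo sapiens) for antiproliferative activity, read by MTT assay, with a stated time of 48 h; a lower number here means a stronger inhibitor, a higher number a weaker inhibitor. Compound 1 `C/C(=C\CC/C(C)=C/CC[C@@H]1[C@@]2(C)CCC(=O)C(C)(C)[C@H]2CC[C@@]1(C)O)CC/C=C(\C)C(=O)OCc1cn(-c2ccc(F)cc2)nn1` carries a 4-fluorophenyl on an aromatic nitrogen. In this assay compound 1 gives only a limit, > 150000 nM. Compound 2 `C/C(=C\CC/C(C)=C/CC[C@@H]1[C@@]2(C)CCC(=O)C(C)(C)[C@H]2CC[C@@]1(C)O)CC/C=C(\C)C(=O)OCc1cn(-c2ccc([N+](=O)[O-])cc2)nn1` carries a 4-nitrophenyl in the same place. Compound 2 likewise reaches only a limit, > 150000 nM. Compound 3 `C/C(=C\CC/C(C)=C/CC[C@@H]1[C@@]2(C)CCC(=O)C(C)(C)[C@H]2CC[C@@]1(C)O)CC/C=C(\C)C(=O)OCc1cn(-c2ccccc2C)nn1` bears a 2-methylphenyl there. For compound 3 the reading is again a limit, > 150000 nM. For the measured compounds named here, because all three sit at the limit of > 150000 nM in this assay, at which 3 of the 3 values shown sit, no step among them can be sized: a step that the two limits leave unreadable from compound 1 to compound 2, a step that the two limits leave unreadable from compound 1 to compound 3 and a step that the two limits leave unreadable from compound 2 to compound 3 all stay hidden. Compound 2 therefore stands at no readable point; its value is one of three that are only limits.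

Compound 4 `C/C(=C\CC/C(C)=C/CC[C@@H]1[C@@]2(C)CCC(=O)C(C)(C)[C@H]2CC[C@@]1(C)O)CC/C=C(\C)C(=O)OCc1cn(-c2cccc(Br)c2)nn1` differs from compound 2 by 3-bromophenyl in place of 4-nitrophenyl on an aromatic nitrogen. Going by the values given here, no measured step speaks directly to this change, and the three that exist give no size at all. Among the compounds with values here, the only guidance is that three different aryl groups on that aromatic nitrogen all left the compound beyond the reach of this assay. The step from compound 2 to compound 4 is therefore expected to be unreadable as well, a step that the limit leaves unreadable from compound 2 to compound 4. Compound 4 is estimated at 200000 nM, with a range from 100000 nM to 600000 nM, and it is expected most likely to be reported as a limit too.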

Compound 4, half-maximal inhibitory concentration: > 150000 nM
Compound 4: only a limit was reported; the forecaster's own chance of this, stated with the estimate: 85%; the middle value is on the limit's open side.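

In this assay compound 4 gives > 150000 nM, a limit and not a number. Its steps to compound 1, compound 2 and compound 3 therefore cannot be read: the limit of > 150000 nM in this assay, at which 4 of the 4 values shown sit.

The compounds shown leave open how the four esters differ in this assay, and whether any aryl group on that aromatic nitrogen would give a readable value there.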